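The compounds below may be only part of what the source reports. "The series", "measured", "known", "first", "only" and "open" are said of these compounds alone.

Measured compounds:
- compound 1 `O=C(O)c1cc(=O)c2c(OCCCCCCCOc3ccccc3)cccc2o1`: 0.8 ug/mL
- compound 2 `O=C(O)c1cc(=O)c2c(OCCCCCCCCCOc3ccccc3)cccc2o1`: 6 ug/mL
- compound 3 `O=C(O)c1cc(=O)c2ccc(OCCCCCOc3ccccc3)cc2o1`: 0.4 ug/mL

Among the measured compounds shown here, in a functional assay on ileum (Cavia porcellus) for antagonist activity, with a stated time of 30 s (on this read-out lower numbers stand for stronger inhibition and higher numbers for weaker inhibition), the one step that can be counted is a 7.5-fold higher number from compound 1 to compound 2 (0.88 log units; beyond the scatter), brought about by 2-phenoxyethyl in place of phenoxy on a saturated chain carbon, seven bonds along the chain from an oxygen on an aromatic ring. Compound 3 and compound 1 carry different cores; how the two cores differ is not broken down here. Their values lie within the usual scatter of each other, so neither is placed above the other.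

Compound 4 `O=C(O)c1cc(=O)c2ccc(OCCCCCCCOc3ccccc3)cc2o1` has not yet been measured in this assay. It differs from compound 3 by 2-phenoxyethyl in place of phenoxy on a saturated chain carbon, five bonds along the chain from an oxygen on an aromatic ring, the same kind of change as from compound 1 to compound 2, though at a different place: five bonds along the chain from the aromatic oxygen rather than seven. Compound 4 is expected to show a step of a 6.3-fold higher number from compound 3 to compound 4 (0.80 log units; beyond the scatter), resting on the earlier step of a 7.5-fold higher number from compound 1 to compound 2 (0.88 log units; beyond the scatter). That earlier step was seen on a different core, so this expectation is held with some caution. Compound 4 is therefore estimated at 2.5 ug/mL, between 0.6 ug/mL and 8 ug/mL.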

Compound 4, half-maximal inhibitory concentration: 1.8 ug/mL
For compound 4 the middle estimate is 1.4-fold (0.14 log units) above the measured one; low and high end bracket the measured number.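

In this assay, 2-phenoxyethyl in place of phenoxy again weakened inhibition, with a 4.5-fold higher number from compound 3 to compound 4 (0.65 log units; beyond the scatter). The change therefore carried from the core of compound 1 to the core of compound 3 in the same direction, and the size of the two steps does not differ beyond the scatter: the same change on two cores in this assay, a 7.5-fold higher number (0.88 log units; beyond the scatter) from compound 1 to compound 2 and a 4.5-fold higher number (0.65 log units; beyond the scatter) from compound 3 to compound 4, 1.7-fold (0.22 log units) apart, within the scatter of two such steps. This rests on one pair of compounds per core, so it does not show that the change would behave alike on any other core or at any other place along the chain, nor does it explain the loss.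

The compounds shown leave open how a chain shorter than these, or an amine in place of phenoxy, would read out. They also leave open what an ester in place of the carboxylic acid would do.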